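Amide replacement on the oxadiazole-pyrrolidine core

The source may hold more compounds than are shown below. What is called first, only, known or untested is meant among the compounds shown, and "the series" means these compounds.

Measured compounds:
compound 1, `O=C(c1ccc(F)c(F)c1)N1CCCC[C@@H]1c1nc(-c2cccc(F)c2)no1`: 1400 nM
compound 2, `O=C(C1CCCC1)N1CCCC1c1nc(-c2cccc(F)c2)no1`: 1000 nM

Of the compounds shown here, two have been tested in an in vitro functional assay on HEK293-A cells for positive allosteric modulation of metabotropic glutamate receptor 5 (Homo sapiens), read by fluorescence and calcium flux, with a stated time of 140 s; on this read-out higher numbers stand for an effect only at larger amounts of compound and lower numbers for an effect already at smaller amounts. Compound 1 gives 1400 nM and compound 2 gives 1000 nM; the two numbers lie within the usual scatter of each other, so neither stands apart from the other. Compound 1 also differs from compound 2 in more than one place, so no single step can be read from them.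

The next compound, compound 3 `O=C(c1ccc(F)cc1)N1CCCC1c1nc(-c2cccc(F)c2)no1`, is reached from compound 2 by one change: 4-fluorophenyl in place of cyclopentyl on a carbonyl carbon. Among the compounds with values here, nothing among the measured pairs isolates this exchange. Compound 1 carries an aromatic amide and gives 1400 nM, which suggests an aromatic group at this carbonyl is at least tolerated. The step of a 1.3-fold lower number from compound 2 to compound 3 (0.10 log units; within the scatter) is therefore expected to be small, if anything slightly downward. Compound 3 is estimated at 800 nM, with a range from 250 nM to 2500 nM.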

Compound 3, half-maximal effective concentration: 3600 nM
Estimate against measurement, compound 3: 4.5-fold (0.65 log units) below, and the stated range ends below it.
By their numbers in this assay, from the lowest: compounds 2 and 1 (each within the scatter of the next); then compound 3.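

In this assay, the exchange of cyclopentyl for 4-fluorophenyl on a carbonyl carbon gives a 3.6-fold higher number from compound 2 to compound 3 (0.56 log units; beyond the scatter) and so shows that this position is not indifferent to the group it carries. This is the first single change that can be read among these compounds, and it puts the aromatic group on the side of the higher number, though the modest step rests on one pair alone. Nothing shown here accounts for this step.

The compounds shown leave open whether the step follows from the aromatic ring itself or from its fluorine, a question that a plain phenyl at this carbonyl carbon would address. They also leave open where a cyclohexyl, a pyridyl or an isopropyl group would fall at this place.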